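The source may report more compounds than this note shows. Statements on the series, on what has been measured and on what is new or still open speak of the compounds shown alone.

Compound 1 `COc1ccc(C2CC(c3ccccc3)=NN2C2=NC(=O)/C(=C3\C(=O)Nc4ccccc43)S2)cc1`: 2380 nM
Compound 2 `O=C1N=C(N2N=C(c3ccccc3)CC2c2ccc(Cl)cc2)S/C1=C1/C(=O)Nc2ccccc21`: 230 nM

In a functional assay on cells (Cancer cell lines, Homo sapiens) for cytotoxicity, read by sulforhodamine B assay, with a stated time of 48 h (on this read-out higher numbers stand for weaker inhibition of growth and lower numbers for stronger inhibition of growth), compound 2 holds the lower of the two numbers measured, separated from compound 1 by the step of a 10-fold lower number from compound 1 to compound 2 (1.01 log units; beyond the scatter). Compound 3 `CN(C)c1ccc(C2CC(c3ccccc3)=NN2C2=NC(=O)/C(=C3\C(=O)Nc4ccccc43)S2)cc1` differs from compound 2 by dimethylamino in place of chloro on an aromatic carbon. For the measured compounds named here, the one measured step bears on this change in reverse: bringing chloro in gave the large drop of a 10-fold lower number from compound 1 to compound 2 (1.01 log units; beyond the scatter), so taking chloro away again is expected to move the number back toward that of compound 1. Compound 3 is therefore expected to give about 1500 nM in this assay, within 400 nM to 5000 nM, an expected step of a 6.5-fold higher number from compound 2 to compound 3 (0.81 log units; beyond the scatter).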

Compound 3, concentration for 50% growth inhibition: 7420 nM
The estimate for compound 3 lay 4.9-fold (0.69 log units) below the measured number; measured number outside the range, above it.
By their numbers in this assay, from the lowest: compound 2; then compound 1; then compound 3.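

In this assay, dimethylamino in place of chloro gives a 32-fold higher number from compound 2 to compound 3 (1.51 log units; beyond the scatter), a larger change than the earlier swap of methoxy for chloro. Dimethylamino also does not simply return the number to the level seen with methoxy, since the change between them gives a 3.1-fold higher number from compound 1 to compound 3 (0.49 log units; beyond the scatter). This single position therefore separates all three groups, with numbers rising from chloro through methoxy to dimethylamino. Nothing measured here explains these differences. Where a bromo group or a carboxylic acid would fall in this order remains open, as does whether any such group could give a lower number than chloro.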